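Adding Chloro to the Core of a Dithiocarbamate Series

This account rests on a few compounds, and the source may have more. Where it says the series, first, only, none or still open, it means among the compounds named here.

Measured in a functional assay on Hs 683 cells (Homo sapiens) for inhibition, read by MTT assay, with a stated time of 72 h; a lower number here means a stronger inhibitor of growth, a higher number a weaker inhibitor of growth:
Compound 1, `OC1CCCN(C(=S)Sc2c(-c3ccc(Br)cc3)[nH]c3ccccc23)C1`, gives 24000 nM.
Compound 2, `CCOC(=O)C1CCN(C(=S)Sc2c(-c3ccc(Br)cc3)[nH]c3ccccc23)CC1`, gives 36000 nM.
Compound 3, `OC1CCCN(C(=S)Sc2c(-c3ccc(Br)cc3)[nH]c3ccc(Cl)cc23)C1`, gives 31000 nM.

Compound 3 differs from compound 1 by one change, (chloro in place of hydrogen on an aromatic carbon). In this assay that change gave a 1.3-fold higher number from compound 1 to compound 3 (0.11 log units; within the scatter), so the two compounds cannot be told apart by this measurement. Compound 2 carries a different ring on the thiocarbonyl nitrogen; the difference between the two cores is not broken down here. Its value sits within the scatter of both compound 1 and compound 3, so no order among the three can be claimed.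

Compound 4, `CCOC(=O)C1CCN(C(=S)Sc2c(-c3ccc(Br)cc3)[nH]c3ccc(Cl)cc23)CC1`, is not yet measured. For the measured compounds named here, it differs from compound 2 by chloro in place of hydrogen on an aromatic carbon, the same change, at the same place on the core, as the one from compound 1 to compound 3. Because that earlier change gave a 1.3-fold higher number from compound 1 to compound 3 (0.11 log units; within the scatter), the step from compound 2 to compound 4 is expected to be of similar size, a 1.3-fold higher number from compound 2 to compound 4 (0.10 log units; within the scatter). Compound 4 is therefore estimated at 45000 nM in this assay, with an expected range from 20000 nM to 100000 nM.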

Compound 4, concentration for 50% growth inhibition: 36000 nM
Beside the measured number, compound 4's estimate is 1.3-fold (0.10 log units) above it; low and high end bracket the measured number.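

In this assay, chloro in place of hydrogen on the core of compound 2 gave no change at the digits printed from compound 2 to compound 4 (within the scatter). Set beside the same change on the core of compound 1, the new step does not differ from the earlier one by more than repeated measurements would: the same change on two cores in this assay, a 1.3-fold higher number (0.11 log units; within the scatter) from compound 1 to compound 3 and no change at the digits printed (within the scatter) from compound 2 to compound 4, 1.3-fold (0.11 log units) apart, within the scatter of two such steps. This shows that, on these two cores, the change leaves the growth-inhibition number within the scatter both times, but neither step is large enough to show whether a real effect of chloro carries from one core to the other, and two pairs cannot establish a rule for the whole series.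

The compounds shown leave open whether a different group at this same place on the core, such as a methoxy group or an amine, would move the number beyond the scatter. They also leave open whether a carboxylic acid on the ring attached to the thiocarbonyl nitrogen would change how chloro behaves.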